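This account rests on a few compounds, and the source may have more. Where it says the series, first, only, none or still open, it means among the compounds named here.

The measured compounds:

Compound 1, `Cc1ccc(S(=O)(=O)N[C@@H](CC(=O)NC(C)(C)C)C(=O)NCCNC(=O)c2cccc(C(C)C)c2)cc1`, in an ADME assay on Karpas-1106P cells (Homo sapiens) for cytotoxicity (a lower number here means that less compound is needed, a higher number that more compound is needed for the effect), gives > 11100 nM, which is a limit of the assay.
Compound 2, `Cc1ccc(S(=O)(=O)N[C@@H](CC(=O)NC(C)(C)C)C(=O)NCCNC(=O)c2ccccc2Cl)cc1`, in this assay gives > 11100 nM, which is also a limit of the assay.

Compound 2 therefore stands at the limit of this assay, and the other compound shown stands there too, as described by the limit of > 11100 nM in this assay, at which 2 of the 2 values shown sit. The step that the two limits leave unreadable from compound 1 to compound 2 cannot be read, since both of its ends are limits rather than numbers. Compound 3, `Cc1ccc(S(=O)(=O)N[C@@H](CC(=O)NC(C)(C)C)C(=O)NCCNS(=O)(=O)c2ccccc2)cc1`, has not yet been measured in this assay. It differs from compound 2 as follows: phenylsulfonyl in place of (2-chlorophenyl)carbonyl on an amine nitrogen. Within the data shown here, no measured step bears on this change directly; the only measured step, a step that the two limits leave unreadable from compound 1 to compound 2, is unreadable and so yields neither a size nor a direction. With both measured compounds sitting at the limit in this assay, compound 3 is expected to sit at that limit as well. The expected step that the limit leaves unreadable from compound 2 to compound 3 is therefore none beyond the scatter. The estimate for compound 3 in this assay is 20000 nM, within 11100 nM to 60000 nM, and most likely it will again be reported only as a limit.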

Compound 3, half-maximal effective concentration: > 11100 nM
Compound 3 gave a limit, no number; the forecaster's own chance of this, stated with the estimate: 85%; the middle value lies beyond the limit too.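

In this assay compound 3 gives > 11100 nM, which is a limit of the assay and not a number. The steps from compound 1 to compound 3 and from compound 2 to compound 3 therefore cannot be read, as the values shown share one limit: the limit of > 11100 nM in this assay, at which 3 of the 3 values shown sit. The compounds shown leave open how far each lies beyond that limit, and so whether phenylsulfonyl in place of (2-chlorophenyl)carbonyl changes the value at all.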